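Trifluoromethoxy to hydroxy on the methylated core

The source may hold more compounds than are shown below. What is called first, only, known or untested is meant among the compounds shown, and "the series" means these compounds.

Compound 1 `Oc1ccc(-c2ccc(-c3ccc(-c4nc5ccccc5[nH]4)cc3)cc2)cc1`: 33300 nM
Compound 2 `Cc1ccc2[nH]c(-c3ccc(-c4ccc(-c5ccccc5)cc4)cc3)nc2c1`: 35200 nM
Compound 3 `Cc1ccc2[nH]c(-c3ccc(-c4ccc(-c5ccc(OC(F)(F)F)cc5)cc4)cc3)nc2c1`: 28300 nM

All three values come from a functional assay on SiHa cells (Homo sapiens) for inhibition, read by sulforhodamine B assay; a higher number here means a weaker inhibitor of growth, a lower number a stronger inhibitor of growth. Compound 3, at 28300 nM, lies within the scatter of both compound 1 and compound 2, so the measured set shows no separation so far.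

The next compound is compound 4 `Cc1ccc2[nH]c(-c3ccc(-c4ccc(-c5ccc(O)cc5)cc4)cc3)nc2c1`. It differs from compound 3 as follows: hydrogen in place of trifluoromethyl on an oxygen on an aromatic ring. This turns trifluoromethoxy into hydroxy.

For the measured compounds named here, only one measured step involves the trifluoromethoxy group: a 1.2-fold lower number from compound 2 to compound 3 (0.09 log units; within the scatter). That step puts the group in place of hydrogen on an aromatic carbon, so it is a related change and not the same one. Hydroxy has not yet been measured on the core of compound 3. Compound 1, which also carries a 4-hydroxyphenyl group on a different core, gives 33300 nM, and this value stays within the scatter of the others. Neither observation points to a real shift, so no step beyond the scatter is expected. The expected change is a 1.1-fold higher number from compound 3 to compound 4 (0.03 log units; within the scatter). For compound 4 the estimated value is 30000 nM, with an expected range of 16000 nM to 55000 nM.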

Compound 4, concentration for 50% growth inhibition: 33500 nM
For compound 4 the middle estimate is 1.1-fold (0.05 log units) below the measured one, and the stated range covers the measured number.
By their numbers in this assay, from the lowest: compounds 3, 1, 4 and 2 (each within the scatter of the next).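

In this assay, replacing trifluoromethoxy with hydroxy gives a 1.2-fold higher number from compound 3 to compound 4 (0.07 log units; within the scatter) and hydroxy in place of hydrogen gives a 1.1-fold lower number from compound 2 to compound 4 (0.02 log units; within the scatter) on the shared core, so hydrogen, trifluoromethoxy and hydroxy at this position are now all measured on one core and are not separated by this read-out. For the compounds shown here, with hydroxy held constant, a first direct reading of the methyl on the core gives a 1.0-fold higher number from compound 1 to compound 4 (0.00 log units; within the scatter) and shows that this second site, in the one pair available, also produces no separation. No supporting data bear on why these steps remain within the scatter.

Going by these compounds, whether a group of another kind at this position, such as an amine or a carboxylic acid, would move the number beyond the scatter remains open, as does the effect of a longer chain such as butoxy in place of hydroxy. Also open is whether any substituent on the core other than methyl would separate compounds in this series, since the four compounds shown cannot be ranked against one another.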